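From compound 3 to a longer chain in compound 4

The compounds below may be only part of what the source reports. "The series", "measured", "known", "first", "only" and "open" are said of these compounds alone.

- compound 1 `CC/C=C\C[C@H]1C(=O)C=C[C@H]1CC(=O)Oc1ccccc1` gives 33000 nM
- compound 2 `CC/C=C\C[C@H]1C(=O)C=C[C@H]1CC(=O)OCc1ccccc1` gives 20000 nM
- compound 3 `CC/C=C\C[C@H]1C(=O)C=C[C@H]1CC(=O)OCCO` gives 24000 nM

All three values come from a functional assay on RAW264.7 cells (Mus musculus) for inhibition, read by ELISA, with a stated time of 24 h (a lower number here means that less compound is needed, a higher number that more compound is needed for the effect), and the read-out is a half-maximal effective concentration. Compound 3 stands at 24000 nM and lies within the scatter of both other compounds, so the three cannot be ranked.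

Compound 4 `CC/C=C\C[C@H]1C(=O)C=C[C@H]1CC(=O)OCCOCCOCCOC` has not been measured yet. It carries 2-(2-methoxyethoxy)ethyl in place of hydrogen on an oxygen on a saturated carbon, and 2-(2-methoxyethoxy)ethyl in place of hydrogen on an oxygen on a saturated carbon gives the counted difference.

The nearest evidence comes from changes to the group on the oxygen next to a carbonyl group. The measured steps were a 1.7-fold lower number from compound 1 to compound 2 (0.22 log units; within the scatter) and a 1.4-fold lower number from compound 1 to compound 3 (0.14 log units; within the scatter) and a 1.2-fold higher number from compound 2 to compound 3 (0.08 log units; within the scatter) and none of them leaves the scatter. Among the compounds with values here, no measured compound carries a chain like the one in compound 4, so these steps are only a loose guide.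

The expected step in this assay is a 1.0-fold higher number from compound 3 to compound 4 (0.02 log units; within the scatter) and it is not expected to exceed the scatter, with no direction favoured. Compound 4 is estimated at 25000 nM with 11000 nM to 55000 nM as the expected range.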

Compound 4, half-maximal effective concentration: 35000 nM
Compound 4: middle estimate off by 1.4-fold (0.15 log units), on the low side, within the range that was stated.
By their numbers in this assay, from the lowest: compounds 2, 3, 1 and 4 (each within the scatter of the next).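

Putting 2-(2-methoxyethoxy)ethyl in place of the hydrogen on an oxygen on a saturated carbon gives a 1.5-fold higher number from compound 3 to compound 4 (0.16 log units; within the scatter) in this assay. The earlier compounds shown here varied only among phenyl, benzyl and 2-hydroxyethyl, whereas this change turns hydroxy into the much longer 2-(2-methoxyethoxy)ethoxy, which has no ring and no hydrogen-bond donor, and the step still does not leave the usual scatter, so this assay gives no sign that the hydroxy hydrogen of compound 3 is needed or that the longer chain makes a measurable difference. No measurement is available that could explain this result or say what the added chain does in the cells.

The compounds shown leave open whether a different kind of group at this place, such as an amine or a carboxylic acid, would give a step beyond the scatter. As far as these compounds go, it also remains open whether a still longer chain of the same type, or a change to the shared core rather than to this chain, would give a step that can be told apart from the scatter.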